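The source may hold more compounds than are shown below. What is called first, only, known or untested is meant among the compounds shown, and "the series" means these compounds.

Measured so far:
compound 1 `CCN(Cc1ccc(Br)cc1)c1ccc(C(=O)N2CCc3ccc(OS(N)(=O)=O)cc3C2)cc1` — 78.2%
compound 2 `NS(=O)(=O)Oc1ccc2c(c1)CN(C(=O)c1cccc(N3CCCCC3)c1)CC2` — 1%

In an assay on HEK293 cells for inhibition of Steryl-sulfatase (Homo sapiens), tested at 0.1 uM (a higher number here means a stronger effect of the compound at the concentration tested, a lower number a weaker effect), compound 1 gives the higher of the two numbers, with compound 2 a long way lower, beyond the scatter. Compound 3 `CCCN(Cc1ccccc1)c1ccc(C(=O)N2CCc3ccc(OS(N)(=O)=O)cc3C2)cc1` has not been measured. Its change from compound 1 is benzyl(propyl)amino in place of (4-bromobenzyl)(ethyl)amino on an aromatic carbon. For the measured compounds named here, with no measured pair covering this change, only a moderate step is expected in this assay, downward from compound 1, since a substituent on the aromatic ring is removed and the chain lengthened by one carbon. Compound 3 is estimated at 60%, within 35% to 82%, which means an expected step of a number 18.2 percentage points lower from compound 1 to compound 3 (beyond the scatter).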

Compound 3, a percentage reported as inhibition, at one concentration (the size of the read-out at that concentration, not a potency): 64.8%
For compound 3 the middle estimate is 4.8 percentage points below the measured one, and the stated range covers the measured number.
By their numbers in this assay, from the lowest: compound 2; then compound 3; then compound 1.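

In this assay, benzyl(propyl)amino in place of (4-bromobenzyl)(ethyl)amino on this aromatic carbon gives a number 13.4 percentage points lower from compound 1 to compound 3 (beyond the scatter), a modest step. The bromine is therefore not required for a substantial read-out at this position, since compound 3 still gives 64.8% at the concentration tested. No measurement available here accounts for the step.

On these data alone, the loss of bromine and the longer chain arrive together, so their separate contributions remain open. Benzyl(ethyl)amino would separate them, and (4-bromobenzyl)(propyl)amino would test the same question from the other side.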